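Acid-bearing aryl ether series: from compound 3 to compound 4

The compounds below may be only part of what the source reports. "The series", "measured", "known", "first", "only" and "open" are said of these compounds alone.

Measured so far in an assay for positive allosteric modulation of metabotropic glutamate receptor 2 (Rattus norvegicus); on this read-out higher numbers stand for an effect only at larger amounts of compound and lower numbers for an effect already at smaller amounts:
Compound 1, `Cc1c(OCCCCOc2cncc(C(=O)O)c2)ccc(C(=O)CC(C)(C)C)c1O`: 490 nM
Compound 2, `Cc1c(OCCCCOc2ccc(F)c(C(=O)N(C)C)c2)ccc(C(=O)CC(C)(C)C)c1O`: 3810 nM
Compound 3, `Cc1c(OC[C@@H](C)COc2ccc(Cl)c(C(=O)O)c2)ccc(C(=O)CC(C)(C)C)c1O`: 377 nM

Compound 3 gives the lowest number of the three; compound 1 lies within the scatter of it, while compound 2 stands beyond the scatter at a higher number. Compound 4, `Cc1cc(OC[C@H](C)COc2ccc(C(=O)CC(C)(C)C)c(O)c2C)ccc1C(=O)O`, is not yet measured. It differs from compound 3 by 4-carboxy-3-methylphenyl in place of 3-carboxy-4-chlorophenyl on an oxygen on a saturated carbon. The carboxylic acid is kept, and the two acids measured so far, compound 1 at 490 nM and compound 3 at 377 nM, both give lower numbers than the amide of compound 2 at 3810 nM. For compound 4 the expected step in this assay is therefore small, at most a modest shift to a higher number, and is estimated as a 1.6-fold higher number from compound 3 to compound 4 (0.20 log units; within the scatter). For compound 4 the estimate is 600 nM, with a range from 200 nM to 2000 nM.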

Compound 4, half-maximal effective concentration: 305 nM
Estimate against measurement, compound 4: 2.0-fold (0.29 log units) above, within the range that was stated.
By their numbers in this assay, from the lowest: compounds 4, 3 and 1 (each within the scatter of the next); then compound 2.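

In this assay, 4-carboxy-3-methylphenyl in place of 3-carboxy-4-chlorophenyl on an oxygen on a saturated carbon gives a 1.2-fold lower number from compound 3 to compound 4 (0.09 log units; within the scatter) and so shows no readable change. At this place, the aryl group can therefore differ in both the site of the carboxylic acid and the chlorine or methyl substituent while the number stays within the scatter. No measurement shown gives a reason for this.

From the compounds shown here alone, the step combines both differences, so their separate contributions remain open. Also open, going by these compounds, is whether a tetrazole in place of the carboxylic acid would hold the number on this chain.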